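The source may hold more compounds than are shown below. What is called first, only, known or untested is meant among the compounds shown, and "the series" means these compounds.

Measured compounds:
- compound 1, `O=C1C(=O)N(CCCOC(=O)c2cn(C3CC3)c3cc(N4CCN(CCCN5C(=O)C(=O)c6ccccc65)CC4)c(F)cc3c2=O)c2ccccc21`, in an ADME assay on Vero cells (Chlorocebus sabaeus) for cytotoxicity, read by MTT assay, with a stated time of 72 h (on this read-out higher numbers stand for lower toxicity in this test and lower numbers for higher toxicity in this test), gives 32 ug/mL
- compound 2, `CCO/N=C1\C(=O)N(CCCN2CCN(c3cc4c(cc3F)c(=O)c(C(=O)OCCCN3C(=O)/C(=N/OCC)c5ccccc53)cn4C3CC3)CC2)c2ccccc21`, gives 32 ug/mL
- compound 3, `Cc1ccc2c(c1)C(=O)C(=O)N2CCCN1CCN(c2cc3c(cc2F)c(=O)c(C(=O)O)cn3C2CC2)CC1`, gives 64 ug/mL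

Compound 3 has the highest of the three numbers in this assay, but its gap to compound 1 and its gap to compound 2 are both within the scatter of repeat measurements, so the three compounds are not separated by this read-out. Among the measured compounds shown here, no pair of measured compounds differs in a single place, so no step size is available from the measured set.

Compound 4, `O=C1C(=O)N(CCCN2CCN(c3cc4c(cc3F)c(=O)c(C(=O)O)cn4C3CC3)CC2)c2ccccc21`, is the next compound to be measured in this assay. It differs from compound 3 in one place:

hydrogen in place of methyl on an aromatic carbon

For the measured compounds named here, with no measured single-point step to draw on, the expectation for the change from compound 3 to compound 4 is a step of no more than the scatter, in no preferred direction, and is given as no change at the digits printed from compound 3 to compound 4 (within the scatter). Compound 4 is accordingly estimated at 64 ug/mL in this assay, with a range from 32 ug/mL to 128 ug/mL.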

Compound 4, half-maximal cytotoxic concentration: 128 ug/mL
Estimate against measurement, compound 4: 2.0-fold (0.30 log units) below; measured number inside the range.
By their numbers in this assay, from the lowest: compounds 1, 2, 3 and 4 (each within the scatter of the next, the first and the last beyond it).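

Compound 3 to compound 4 gives the series its first single-place comparison: in this assay, hydrogen in place of methyl on an aromatic carbon reads as a 2.0-fold higher number from compound 3 to compound 4 (0.30 log units; within the scatter). At this position, on the six-membered aromatic ring of carbon only, methyl and hydrogen are therefore not separated by this read-out, so the methyl is not needed for the values seen here. Nothing measured on these compounds offers an explanation for this reading.

As far as these compounds go, whether a methoxy group, a chlorine or an amine on the same aromatic carbon would give a step beyond the scatter remains open. Also open, from the compounds shown here alone, is whether hydrogen in place of methyl reads the same way when an ester stands in place of the carboxylic acid.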